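The source may hold more compounds than are shown below. What is called first, only, known or untested is meant among the compounds shown, and "the series" means these compounds.

Three measured compounds share one core and differ only in the aryl group attached to it. Compound 1 `O=Cc1ccc(-c2cn3ccnc3c(-c3ccc4ncn(C5CCCCC5)c4c3)n2)cc1` carries a 4-formylphenyl group and, in a functional assay on RPMI-8226 cells (Homo sapiens) for inhibition, read by sulforhodamine B assay, with a stated time of 48 h, tested at 10 uM (on this read-out higher numbers stand for more inhibition at the one concentration tested (going by the name of the read-out) and lower numbers for less inhibition), compound 1 gives 82.5%. Compound 2 `Clc1ccc(-c2cn3ccnc3c(-c3ccc4ncn(C5CCCCC5)c4c3)n2)cc1` carries a 4-chlorophenyl group, and in this assay compound 2 gives 19%. Compound 3 `COc1ccccc1-c1cn2ccnc2c(-c2ccc3ncn(C4CCCCC4)c3c2)n1` carries a 2-methoxyphenyl group, and in this assay compound 3 gives 35.9%. Compound 3 therefore stands second of the three: the change from compound 1 is a number 46.6 percentage points lower from compound 1 to compound 3 (beyond the scatter), and the change from compound 2 is a number 16.9 percentage points higher from compound 2 to compound 3 (beyond the scatter).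

Compound 4 `Fc1ccccc1-c1cn2ccnc2c(-c2ccc3ncn(C4CCCCC4)c3c2)n1` arises from compound 3 by one change: fluoro in place of methoxy on an aromatic carbon. Among the measured compounds shown here, no measured step swaps a methoxy for a fluoro, so the bearing of the known steps is indirect. The step of a number 16.9 percentage points higher from compound 2 to compound 3 (beyond the scatter) shows that a halogen-bearing phenyl sat lower than the methoxyphenyl, and a number 63.5 percentage points lower from compound 1 to compound 2 (beyond the scatter) shows that the halogen compound sits far below the formyl compound. A step downward of modest size is therefore expected, a number 9.9 percentage points lower from compound 3 to compound 4 (within the scatter). Compound 4 is estimated at 26% in this assay, with a range from 8% to 45%.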

Compound 4, a percentage reported as inhibition, at one concentration (the size of the read-out at that concentration, not a potency): 42.4%
Estimate against measurement, compound 4: 16.4 percentage points below; measured number inside the range.
By their numbers in this assay, from the lowest: compound 2; then compounds 3 and 4 (each within the scatter of the next); then compound 1.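

At this place, on an aromatic carbon ortho to a large group, swapping methoxy for fluoro gives a number 6.5 percentage points higher from compound 3 to compound 4 (within the scatter) in this assay, so this read-out does not separate the two groups, even though fluoro has one heavy atom and no hydrogen-bond acceptor while methoxy has two heavy atoms and one hydrogen-bond acceptor. A halogen on the aryl group does not by itself tie a compound to the low number of compound 2, since replacing 4-chlorophenyl with 2-fluorophenyl gives a number 23.4 percentage points higher from compound 2 to compound 4 (beyond the scatter) and yet that step changes both the halogen and its place, so the two changes cannot be told apart. The 4-formylphenyl group still stands clear of this fluoro compound, as the step of a number 40.1 percentage points lower from compound 1 to compound 4 (beyond the scatter) shows, and so the fluoro swap adds a second group at this place without closing the distance to compound 1.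

Nothing available gives a reason for any of these numbers. Going by these compounds, it remains open how an amine, a carboxylic acid or a longer chain would read at this same place, and whether a formyl group placed there would behave like the 4-formylphenyl group of compound 1.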